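This account rests on a few compounds, and the source may have more. Where it says the series, first, only, none or still open, it means among the compounds named here.

Measured compounds:
Compound 1 `CN(C)CC[C@H](CSc1ccccc1)Nc1ccc(S(=O)(=O)NC(=O)c2ccc(N3CCN(Cc4ccccc4-c4ccc(Cl)cc4)CC3)cc2)cc1C(F)(F)F` — in an assay on isolated protein for displacement of a labelled ligand from Apoptosis regulator Bcl-2 (Homo sapiens), read by fluorescence polarization (a lower number here means a stronger inhibitor, a higher number a weaker inhibitor), compound 1 gives < 1 nM, which is a limit of the assay and not a number.
Compound 2 `CN(C)CC[C@H](CSc1ccccc1)Nc1ccc(S(=O)(=O)NC(=O)c2ccc(N3CCN(CC4=C(c5ccc(Cl)cc5)CCC(C)(C)C4)CC3)cc2)cc1[N+](=O)[O-]` — in this assay compound 2 gives < 1 nM, again a limit.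
Compound 3 `CN(C)CC[C@H](CSc1ccccc1)Nc1ccc(S(=O)(=O)NC(=O)c2ccc(N3CCN(C/C4=C(\c5ccc(Cl)cc5)CCCCCC4)CC3)cc2)cc1[N+](=O)[O-]` — in this assay compound 3 gives < 1 nM, again a limit.

Compound 1 therefore stands where every value of the series stands: the limit of < 1 nM in this assay, at which 3 of the 3 values shown sit. Within the data shown here, the three values show only that no compound has yet been separated from the others by a number, so no order among them can be drawn.

Compound 4 `CN(C)CC[C@H](CSc1ccccc1)Nc1ccc(S(=O)(=O)NC(=O)c2ccc(N3CCN(Cc4ccccc4-c4ccc(Cl)cc4)CC3)cc2)cc1C(=O)C(F)(F)F` differs from compound 1 in one place, ((trifluoromethyl)carbonyl in place of trifluoromethyl on an aromatic carbon). Among the measured compounds shown here, no measured pair covers a change of this kind, so nothing in the data points to a direction. The expected step in this assay is a number no lower from compound 1 to compound 4 (the limit leaves the size open), none beyond the scatter. For compound 4 the estimate in this assay is 1 nM, with a range from 0.3 nM to 4 nM; a further limit rather than a number is the more likely outcome.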

Compound 4, inhibition constant: < 1 nM
Compound 4: no number, only a limit; the forecaster's own chance of this, stated with the estimate: 60%; the middle value sits exactly at the limit.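

Among these compounds, compound 4 gives < 1 nM in this assay, a limit and not a number, as is the value of compound 1, so no step between compound 1 and compound 4 can be read. The compounds shown leave open any order among them, with all values at one place: the limit of < 1 nM in this assay, at which 4 of the 4 values shown sit.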